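The source may hold more compounds than are shown below. What is called first, only, known or untested is meant among the compounds shown, and "the series" means these compounds.

Three compounds built on one shared core were examined in an ADME assay on Vero cells (Chlorocebus sabaeus) for cytotoxicity, read by MTT assay, with a stated time of 96 h; a lower number here means that less compound is tolerated, a higher number that more compound is tolerated. Compound 1 `C/C(=N\NC(N)=O)c1ccc2[nH]c(-c3ccc(Cl)cc3)nc2c1` gives > 100000 nM there, which is a limit of the test and not a number. Compound 2 `C/C(=N\NC(N)=O)c1ccc2[nH]c(-c3ccc(C(F)(F)F)cc3)nc2c1` differs from compound 1 by trifluoromethyl in place of chloro on an aromatic carbon. In this assay compound 2 gives > 100000 nM, again a limit. Compound 3 `C/C(=N\NC(N)=S)c1ccc2[nH]c(-c3ccc(Cl)cc3)nc2c1` differs from compound 1 by a group of 3 heavy atoms (1 carbon, 1 nitrogen, 1 sulfur; no ring) in place of a group of 3 heavy atoms (1 carbon, 1 nitrogen, 1 oxygen; no ring), on an amine nitrogen. In this assay compound 3 gives > 100000 nM, also a limit. The step that the two limits leave unreadable from compound 1 to compound 2 and the step that the two limits leave unreadable from compound 1 to compound 3 therefore cannot be sized, because every value sits at the limit of > 100000 nM in this assay, at which 3 of the 3 values shown sit.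

Compound 4 `C/C(=N\NC(N)=S)c1ccc2[nH]c(-c3ccc(C(F)(F)F)cc3)nc2c1` has not yet been measured. It differs from compound 3 by trifluoromethyl in place of chloro on an aromatic carbon, the same change that takes compound 1 to compound 2, made at the same place. The step that the limit leaves unreadable from compound 3 to compound 4 is expected to be unreadable in the same way. The change left compound 2 at its limit, so compound 4 is expected to give 150000 nM in this assay.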

Compound 4, half-maximal cytotoxic concentration: 22000 nM
Compound 4: the middle estimate sits 6.8-fold (0.83 log units) above what was measured; the measured number lies below the stated range.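

In this assay, trifluoromethyl in place of chloro on the core of compound 3 gives an at least 4.5-fold lower number from compound 3 to compound 4 (0.65 log units; beyond the scatter), so on this core the change has a readable effect on how much compound the cells tolerate. The other change, the sulfur-bearing group in place of the oxygen-bearing group with trifluoromethyl already present, gives an at least 4.5-fold lower number from compound 2 to compound 4 (0.65 log units; beyond the scatter), so compound 4 is the only compound shown with a number below the limit, and it carries both changes. This does not show that the trifluoromethyl change acts differently on the two cores, nor that it acts alike, because the steps from compound 1 to compound 2 and from compound 1 to compound 3 cannot be read: the limit of > 100000 nM in this assay, at which 3 of the 4 values shown sit.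

The compounds shown leave open how an amine, a methoxy group or a carboxylic acid in place of chloro would read in this assay. They also leave open what a longer chain on the amine nitrogen would do on either core.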